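Removing the Fluorine: Compound 1 to Compound 4

This account rests on a few compounds, and the source may have more. Where it says the series, first, only, none or still open, it means among the compounds named here.

Measured compounds:
compound 1 `CC(Sc1nc2c(cnn2C)c(=O)n1-c1ccccc1)c1cccc(F)c1` — 151 nM
compound 2 `COc1ccccc1C(C)Sc1nc2c(cnn2C)c(=O)n1-c1ccccc1` — 445 nM
compound 3 `COc1ccc(C(C)Sc2nc3c(cnn3C)c(=O)n2-c2ccccc2)cc1` — 352 nM

All three were tested in an assay on isolated protein for inhibition of aldehyde dehydrogenase 1A1 (Homo sapiens); on this read-out higher numbers stand for weaker inhibition and lower numbers for stronger inhibition. Among them compound 1 gives the lowest number, with compound 3 nearest and compound 2 furthest away. The two steps from compound 1 show what happens when the aromatic ring on the chain is changed: a 2.9-fold higher number from compound 1 to compound 2 (0.47 log units; beyond the scatter) and a 2.3-fold higher number from compound 1 to compound 3 (0.37 log units; beyond the scatter), both modest weakenings beyond the scatter. Between compound 2 and compound 3 the step is a 1.3-fold lower number from compound 2 to compound 3 (0.10 log units; within the scatter), within the scatter.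

Compound 4 `C[C@H](Sc1nc2c(cnn2C)c(=O)n1-c1ccccc1)c1ccccc1` has not yet been measured. Relative to compound 1 the change is 1-phenylethyl in place of 1-(3-fluorophenyl)ethyl on a sulfur. This is a smaller alteration than either measured step, and the fluorine simply leaves rather than a methoxy entering, so the expectation for this assay is a step within the scatter or a slight weakening, as in a 2.3-fold higher number from compound 1 to compound 3 (0.37 log units; beyond the scatter). The estimated step is a 1.4-fold higher number from compound 1 to compound 4 (0.14 log units; within the scatter). Compound 4 is thus expected to give about 210 nM, with a range from 80 nM to 550 nM.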

Compound 4, half-maximal inhibitory concentration: 1410 nM
Compound 4: middle estimate off by 6.7-fold (0.83 log units), on the low side; measured number outside the range, above it.
By their numbers in this assay, from the lowest: compound 1; then compounds 3 and 2 (each within the scatter of the next); then compound 4.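

Small as it looks, losing the fluorine from the 1-(3-fluorophenyl)ethyl group on the sulfur is the largest change seen so far in this assay, with a 9.3-fold higher number from compound 1 to compound 4 (0.97 log units; beyond the scatter). The unsubstituted 1-phenylethyl group also gives a higher number than either methoxy-bearing ring, compound 2 at 445 nM and compound 3 at 352 nM, so any of these three ring substituents gives a lower number here than the bare ring does. No supporting data explain this difference.

Compound 4 also has a defined stereocentre, unlike compound 1 as drawn, and the compounds shown cannot separate that difference from the loss of fluorine. They also leave open how a chlorine or a trifluoromethyl group in the fluorine's place would compare.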